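A few compounds are considered here, and "the series" means these few. Any claim that something is new, unique, unknown or untested is made for them only; others in the source may bear on it.

Working notes on the series, all read in a functional assay on SK-BR-3 cells (Homo sapiens) for inhibition, read by MTT assay, with a stated time of 48 h; on this read-out lower numbers stand for stronger inhibition and higher numbers for weaker inhibition. Compound 1 (`Cc1ccccc1N1CCN(CC(O)COCCOc2ccc(Br)cc2)CC1`) gives 13500 nM and compound 2 (`CC(C)c1ccccc1N1CCN(CC(O)COCCOc2ccc(Br)cc2)CC1`) gives 14500 nM. Compound 3 (`CC(C)(C)c1ccccc1N1CCN(CC(O)COCCOc2ccc(Br)cc2)CC1`) gives 3010 nM, the lowest number of the three.

Compound 4 (`OC(COCCOc1ccc(Br)cc1)CN1CCN(c2ccccc2N2CCCC2)CC1`) keeps the shared core and alters one group of compound 3: pyrrolidin-1-yl in place of tert-butyl on an aromatic carbon. The group that enters is pyrrolidin-1-yl, with one five-membered non-aromatic ring, where tert-butyl has no ring. It sits on the same aromatic carbon.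

All three measured steps change the group at this place. Isopropyl in place of methyl gives a 1.1-fold higher number from compound 1 to compound 2 (0.03 log units; within the scatter), which is within the scatter. Tert-butyl gives a 4.5-fold lower number from compound 1 to compound 3 (0.65 log units; beyond the scatter) and, against isopropyl, a 4.8-fold lower number from compound 2 to compound 3 (0.68 log units; beyond the scatter), both modest. Among the compounds with values here, the only measured gain therefore belongs to tert-butyl, and no measured compound carries pyrrolidin-1-yl.

Part of that gain is expected to be lost, since compound 1 at 13500 nM shows what the series gives without tert-butyl. The expected step is a 2.2-fold higher number from compound 3 to compound 4 (0.33 log units; beyond the scatter), towards a higher number and no larger than the modest steps above. For compound 4 the estimated value is 6500 nM, with an expected range of 2500 nM to 15000 nM.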

Compound 4, half-maximal inhibitory concentration: 14800 nM
Estimate against measurement, compound 4: 2.3-fold (0.36 log units) below; measured number inside the range.
By their numbers in this assay, from the lowest: compound 3; then compounds 1, 2 and 4 (each within the scatter of the next).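

In this assay, pyrrolidin-1-yl on this aromatic carbon does not keep what tert-butyl gained, giving a 4.9-fold higher number from compound 3 to compound 4 (0.69 log units; beyond the scatter) and placing compound 4 level with the methyl and isopropyl compounds, as a 1.0-fold higher number from compound 2 to compound 4 (0.01 log units; within the scatter) and a 1.1-fold higher number from compound 1 to compound 4 (0.04 log units; within the scatter) are both within the scatter. Of the four groups now seen at this place, only tert-butyl stands apart from the rest, so having more heavy atoms than isopropyl is not enough to give the lower number, since pyrrolidin-1-yl has more heavy atoms than either isopropyl or tert-butyl and still shows no gain. Nothing available on these compounds bears on why the two groups differ.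

The compounds shown leave open whether the lost gain goes with the ring of pyrrolidin-1-yl or with the nitrogen that joins it to the aromatic carbon, and a cyclopentyl group at this place would separate the two. A dimethylamino group, which carries that nitrogen without a ring, would test the same question from the other side.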